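The compounds below may be only part of what the source reports. "The series", "measured", "known", "first", "only" and "open" are said of these compounds alone.

Three compounds of the series carry numbers in an in vitro assay on HEK385-7 cells for displacement of a labelled ligand from prostaglandin D2 receptor 2 (Homo sapiens); a higher number here means a weaker inhibitor, a lower number a stronger inhibitor. Compound 1 `NS(=O)(=O)c1ccc(-c2nc(C(c3ccc(F)cc3)c3ccc(F)cc3)sc2CC(=O)O)cc1` gives 1500 nM. Compound 2 `O=C(O)Cc1sc(C(c2ccc(F)cc2)c2ccc(F)cc2)nc1-c1cc(F)nc(F)c1` gives 5.4 nM, and compound 3 `O=C(O)Cc1sc(C(c2ccc(F)cc2)c2ccc(F)cc2)nc1-c1ccnc(O)c1` gives 68 nM. Compound 3 thus holds the second highest of the three numbers: the step of a 13-fold higher number from compound 2 to compound 3 (1.10 log units; beyond the scatter) and the step of a 22-fold lower number from compound 1 to compound 3 (1.34 log units; beyond the scatter) both lie beyond the scatter, and the step of a 280-fold lower number from compound 1 to compound 2 (2.44 log units; beyond the scatter) spans the whole range seen so far.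

Compound 4 `CN(C)c1cc(-c2nc(C(c3ccc(F)cc3)c3ccc(F)cc3)sc2CC(=O)O)ccn1` differs from compound 3 in one place: dimethylamino in place of hydroxy on an aromatic carbon. Among the compounds with values here, no measured step exchanges one substituent on that six-membered aromatic ring for another of this kind. The nearest is the step of a 13-fold higher number from compound 2 to compound 3 (1.10 log units; beyond the scatter), which shows that what sits on the ring moves the number well beyond the scatter; the steps starting from compound 1 exchange the whole aryl group and say less about this change. The direction of the step in this assay is therefore uncertain; a moderate move toward a lower number is taken as the best guess, with a result inside the scatter not excluded.

For compound 4 the number expected in this assay is 35 nM, with a range of 8 nM to 150 nM, which means an expected step of a 1.9-fold lower number from compound 3 to compound 4 (0.29 log units; within the scatter).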

Compound 4, half-maximal inhibitory concentration: 380 nM
For compound 4 the middle estimate is 11-fold (1.04 log units) below the measured one; the whole stated range lies below it.
By their numbers in this assay, from the lowest: compound 2; then compound 3; then compound 4; then compound 1.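

Within the data shown here, at the ring carbon next to the ring nitrogen, the exchange of hydroxy for dimethylamino gives a 5.6-fold higher number from compound 3 to compound 4 (0.75 log units; beyond the scatter) in this assay, the first measured swap of one substituent for another at this place, and it favours hydroxy over dimethylamino. The 2-(dimethylamino)pyridin-4-yl group thus sits in the middle of the aryl groups seen so far: a 70-fold higher number from compound 2 to compound 4 (1.85 log units; beyond the scatter) separates it from 2,6-difluoropyridin-4-yl, while a 3.9-fold lower number from compound 1 to compound 4 (0.60 log units; beyond the scatter) still leaves it ahead of 4-sulfamoylphenyl. No supporting measurement is available that accounts for these steps.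

The exchange changes both the heavy-atom count and the hydrogen-bond donor count at once, so the compounds shown do not tell which of the two goes with the rise in the number; amino, methylamino and methoxy at the same place would pull these apart. Also open, on these data alone, is whether a single fluorine next to the ring nitrogen, without the second one of compound 2, keeps the low number of that compound.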